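The source may hold more compounds than are shown below. What is called first, only, known or untested is meant among the compounds shown, and "the series" means these compounds.

Measured so far in an in vitro ADME assay on microsomes from liver (Homo sapiens) for metabolic stability; on this read-out lower numbers stand for a shorter-lived compound and higher numbers for a longer-lived compound:
compound 1 `CC(C)CCn1nc(-c2cccs2)c(O)c(C2=NS(=O)(=O)c3cc(OCC(N)=O)ccc3N2)c1=O` — 0.383 h
compound 2 `NC(=O)COc1ccc2c(c1)S(=O)(=O)N=C(c1c(O)c(-c3cccs3)nn(Cc3ccccc3)c1=O)N2` — 0.383 h

In this assay compound 1 gives 0.383 h and compound 2 gives 0.383 h; the step from compound 1 to compound 2 reads no change at the digits printed from compound 1 to compound 2 (within the scatter), so compound 1 stands level with compound 2 and the two cannot be ordered.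

Compound 3 `CC(C)CCn1nc(-c2nccs2)c(O)c(C2=NS(=O)(=O)c3cc(OCC(N)=O)ccc3N2)c1=O` is not yet measured. It differs from compound 1 by 1,3-thiazol-2-yl in place of thiophen-2-yl on an aromatic carbon, on an aromatic carbon of the shared core, ortho to a hydroxy group and meta to the isopentyl group.

For the measured compounds named here, the one measured step concerns the chain on the ring nitrogen, not this aromatic carbon, and it was flat: no change at the digits printed from compound 1 to compound 2 (within the scatter). Going by the values given here, no measured step bears directly on the exchange of thiophen-2-yl for 1,3-thiazol-2-yl, so the only ground for an expectation is that the single change seen so far on this core left this assay unchanged. For compound 3 a step of a 1.0-fold higher number from compound 1 to compound 3 (0.02 log units; within the scatter) is expected, no clear direction beyond the scatter, giving an estimated 0.4 h with a range from 0.2 h to 0.9 h.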

Compound 3, half-life: > 1 h
Compound 3: only a limit was reported (the forecaster's own chance of this, stated with the estimate: 5%); middle value at least 2.5-fold (0.39 log units) from the limit.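

In this assay, the aromatic carbon ortho to a hydroxy group on the shared core responds to substitution, with 1,3-thiazol-2-yl in place of thiophen-2-yl giving an at least 2.6-fold higher number from compound 1 to compound 3 (0.41 log units; beyond the scatter). The change at the ring-nitrogen chain gave no change at the digits printed from compound 1 to compound 2 (within the scatter), so of the two places shown, only this aromatic carbon separates compounds in this read-out. Compound 3 reads > 1 h, which is a limit and not a number: the limit of > 1 h in this assay, at which 1 of the 3 values shown sits.

The compounds shown do not tell whether the gain comes from the added ring nitrogen itself, or whether the same exchange would hold with the chain of compound 2 on the ring nitrogen. They also leave open how an amine or a carboxylic acid on this aromatic carbon would read in this assay.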